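Iodo in place of ethyl on the aromatic carbon

The source may report more compounds than this note shows. Statements on the series, on what has been measured and on what is new or still open speak of the compounds shown alone.

Compound 2 `CCc1ccccc1N1C(N)=NC(N)=NC1(C)C` gives 4.02 in an assay for inhibition of Dihydrofolate reductase (Bos taurus), at pH 6.25; a higher number here means a more potent compound, by a factor of ten per unit of this negative logarithm, a lower number a less potent compound; compound 1 `CC1(C)N=C(N)N=C(N)N1c1ccccc1N` gives 4.11 in this assay, and the two stand within the scatter of each other. Compound 3 `CC1(C)N=C(N)N=C(N)N1c1ccccc1I` differs from compound 2 by iodo in place of ethyl on an aromatic carbon. Going by the values given here, the only measured step, a number 0.09 log units lower from compound 1 to compound 2 (within the scatter), changed the same aromatic carbon and stayed within the scatter, so no step beyond the scatter is expected in this assay here either. For compound 3 the estimated value is 4.1, range 3.6 to 4.6. The expected step is a number 0.08 log units higher from compound 2 to compound 3 (within the scatter).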

Compound 3, logarithm of the reciprocal of the active concentration, log(1/C): 3.43
Estimate against measurement, compound 3: 0.67 log units above; measured number outside the range, below it.
By their numbers in this assay, from the lowest: compound 3; then compounds 2 and 1 (each within the scatter of the next).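

In this assay this aromatic carbon proves sensitive to its substituent, with iodo in place of ethyl giving a number 0.59 log units lower from compound 2 to compound 3 (beyond the scatter) and iodo in place of amino giving a number 0.68 log units lower from compound 1 to compound 3 (beyond the scatter). Ethyl and amino stand within the scatter of each other, so among these three groups only iodo separates, on the low side. Nothing available accounts for this separation. As far as these compounds go, whether chloro or fluoro on this carbon would stay with ethyl and amino or fall with iodo remains open. The same holds for methoxy.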